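Three Well-Tolerated Analogues and a Fourth to Be Tested

A few compounds are considered here, and "the series" means these few. Any claim that something is new, unique, unknown or untested is made for them only; others in the source may bear on it.

Compound 1, `CC(=O)N(Cc1ccccc1)Cc1ncnc2c1ncn2[C@@H]1O[C@H](CO)[C@@H](O)[C@H]1O`, gives only a limit in a functional assay on Huh-7 cells (Homo sapiens) for cytotoxicity, read by MTT assay, with a stated time of 3 days (a higher number here means that more compound is tolerated, a lower number that less compound is tolerated), namely > 100000 nM.
Compound 2, `OC[C@H]1O[C@@H](n2cnc3c(CSc4ccccc4)ncnc32)[C@H](O)[C@@H]1O`, is likewise reported only as a limit, > 100000 nM.
Compound 3, `CC(=O)N(Cc1ncnc2c1ncn2[C@@H]1O[C@H](CO)[C@@H](O)[C@H]1O)C1CCCCC1`, again gives no number but a limit, > 100000 nM.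

Compound 2 therefore stands where every measured compound stands: at the limit of this assay, with no number to rank it against the others. Within the data shown here, the one change that swaps a single group between measured compounds, a step that the two limits leave unreadable from compound 1 to compound 3, joins two limits and so has no readable size; it shows only that the exchange left both compounds tolerated up to the highest concentration tested.

Compound 4, `O=C(O)CNCc1ncnc2c1ncn2[C@@H]1O[C@H](CO)[C@@H](O)[C@H]1O`, differs from compound 2 by (carboxymethyl)amino in place of phenylsulfanyl on a saturated chain carbon bound to an aromatic carbon. Among the measured compounds shown here, no measured step touches a change of this kind, so the only guide is the limit of > 100000 nM in this assay, at which 3 of the 3 values shown sit. On that basis no step beyond the scatter can be read in either direction, and the most likely outcome is that compound 4 is again reported only as a limit.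

Compound 4 is thus expected to give about 150000 nM, within a range of 50000 nM to 500000 nM. The estimated step that the limit leaves unreadable from compound 2 to compound 4 is expected to be one that the limit itself hides.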

Compound 4, half-maximal cytotoxic concentration: > 100000 nM
Compound 4: a limit, no number; the forecaster's own chance of this, stated with the estimate: 85%; the middle value is on the limit's open side.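

Compound 4, like compound 2, is reported only as a limit, so no new step can be read between compound 2 and compound 4, and the result simply joins a single shared reading: the limit of > 100000 nM in this assay, at which 4 of the 4 values shown sit.

The compounds shown leave open at what concentration, if any, each would harm the cells in this assay, and whether any of these changes alters that concentration.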